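The compounds below may be only part of what the source reports. "The series", "measured", "known", "first", "only" and "open" are said of these compounds alone.

Of the compounds shown here, three of a shared core have been measured in a functional assay on SMMC-7721 cells (Homo sapiens) for inhibition, read by CCK-8 assay, with a stated time of 72 h, tested at 2 uM; on this read-out lower numbers stand for less inhibition of growth and higher numbers for more inhibition of growth at the one concentration tested. Compound 1, `Nc1ccccc1NC(=O)c1ccc(CSc2ccc(Br)cc2)cc1`, carries a 4-bromophenyl on the sulfur and gives 10%. Compound 2, `CC(C)(C)c1ccc(SCc2ccc(C(=O)Nc3ccccc3N)cc2)cc1`, gives 23.6%, and compound 3, `Cc1cc(C)cc(SCc2ccc(C(=O)Nc3ccccc3N)cc2)c1`, gives 29.1%. Compound 3 stands highest of the three numbers; the gap to compound 2 lies within the scatter, while the step of a number 19.1 percentage points higher from compound 1 to compound 3 (beyond the scatter) lies beyond it, as does a number 13.6 percentage points higher from compound 1 to compound 2 (beyond the scatter).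

Compound 4, `Nc1ccccc1NC(=O)c1ccc(CSc2ccc(F)cc2)cc1`, is not yet measured. It differs from compound 3 in one place: 4-fluorophenyl in place of 3,5-dimethylphenyl on a sulfur. The measured step that bears on this change is a number 19.1 percentage points higher from compound 1 to compound 3 (beyond the scatter), since compound 1 also carries a 4-halophenyl on the sulfur; compound 4 walks that step back, with fluorine in place of bromine. A drop of similar size is therefore expected, landing compound 4 near the value of compound 1. The expected step is a number 16.1 percentage points lower from compound 3 to compound 4 (beyond the scatter), giving an estimated 13% for compound 4, with a range from 3% to 25%.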

Compound 4, percent growth inhibition at one concentration: 6.58%
Compound 4: the middle estimate sits 6.4 percentage points above what was measured; the measured number falls inside the stated range.
By their numbers in this assay, from the lowest: compounds 4 and 1 (each within the scatter of the next); then compounds 2 and 3 (each within the scatter of the next).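

In this assay the step of a number 3.4 percentage points lower from compound 1 to compound 4 (within the scatter) stays within the scatter, which shows that fluoro in place of bromo on this aromatic carbon does not separate the two 4-halophenyl compounds. For the compounds shown here, the steps of a number 22.5 percentage points lower from compound 3 to compound 4 (beyond the scatter) and a number 17 percentage points lower from compound 2 to compound 4 (beyond the scatter) lie beyond the scatter, and together with the earlier steps they divide these four compounds into two groups on the sulfur: the 4-halophenyl compounds 1 and 4 on one side, and the alkyl-bearing compounds 2 and 3 on the other. Nothing available explains why these groups on the sulfur separate in this way.

From the compounds shown here alone, it remains open where an unsubstituted phenyl, a 4-methoxyphenyl, a 4-aminophenyl or a cyclohexyl on the sulfur would fall relative to these two groups. Going by these compounds, with a single concentration tested, how the compounds compare across a range of concentrations also remains open.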